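Building a Fluorophenyl-Substituted Analogue on a Bicyclic Diol Core

The source may report more compounds than this note shows. Statements on the series, on what has been measured and on what is new or still open speak of the compounds shown alone.

Measured compounds:
Compound 1, `Cc1cc(CO)c2n1CSC2`, in a functional assay on MCF7 cells (Homo sapiens) for cytotoxicity, read by MTT assay, with a stated time of 72 h (on this read-out lower numbers stand for stronger inhibition and higher numbers for weaker inhibition), compound 1 gives 40900 nM.
Compound 2, `OCc1cn2c(c1CO)CS[C@@H]2c1ccccc1`, for compound 2 the result in this assay is "not determined" (no result reported).
Compound 3, `OCc1cn2c(c1CO)CS[C@@H]2c1cccnc1`, in this assay compound 3 gives 61700 nM.

Compound 2 has no number of its own; the two measured relatives, compound 1 and compound 3, both sit in the weak range shown above. Compound 4, `OCc1c(CO)c(-c2ccc(F)cc2)n2c1CS[C@@H]2c1ccccc1`, differs from compound 2 by 4-fluorophenyl in place of hydrogen on an aromatic carbon. Among the compounds with values here, no measured pair tells what such a step does here, so only a weak-range value, near those of compound 1 and compound 3, is expected. For compound 4 the estimated value in this assay is 50000 nM, between 15000 nM and 200000 nM.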

Compound 4, half-maximal inhibitory concentration: 44600 nM
For compound 4 the middle estimate is 1.1-fold (0.05 log units) above the measured one, and the stated range covers the measured number.
By their numbers in this assay, from the lowest: compounds 1, 4 and 3 (each within the scatter of the next).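

In this assay, within the data shown here, compound 2 carries no number, so no step to compound 4 can be read, and no other data here bear on the result. From the compounds shown here alone, what adding 4-fluorophenyl does to the value of compound 2 stays open.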